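A Methyl in Place of the Bromo Group on Compound 2

A few compounds are considered here, and "the series" means these few. Any claim that something is new, unique, unknown or untested is made for them only; others in the source may bear on it.

For the measured compounds named here, compound 2 `C=CCn1c(=O)/c(=C\c2cccc(Br)c2)[nH]c(=O)/c1=C\c1ccccc1OC` gives the lowest of the two numbers measured so far in a functional assay on U-937 cells (Homo sapiens) for cytotoxicity, read by CCK-8 assay, with a stated time of 72 h (a higher number here means a weaker inhibitor, a lower number a stronger inhibitor), at 1100 nM. Compound 1 `C=CCn1c(=O)/c(=C\c2cccc(F)c2)[nH]c(=O)/c1=C\c1ccccc1OC` gives 2500 nM in this assay, and the step of a 2.3-fold lower number from compound 1 to compound 2 (0.36 log units; beyond the scatter) is the only one measured. Compound 3 `C=CCn1c(=O)/c(=C\c2cccc(C)c2)[nH]c(=O)/c1=C\c1ccccc1OC` differs from compound 2 by methyl in place of bromo on an aromatic carbon. That one measured step concerns a different exchange at the same aromatic carbon and gives no direct guide, so no step beyond the scatter is expected for compound 3, with a slight lean toward a higher number, a 1.4-fold higher number from compound 2 to compound 3 (0.13 log units; within the scatter). Compound 3 is expected to give about 1500 nM, within 700 nM to 3200 nM.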

Compound 3, half-maximal inhibitory concentration: 5100 nM
Compound 3: the middle estimate sits 3.4-fold (0.53 log units) below what was measured; measured number above the stated range.
By their numbers in this assay, from the lowest: compound 2; then compound 1; then compound 3.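

In this assay methyl gives a 4.6-fold higher number from compound 2 to compound 3 (0.67 log units; beyond the scatter) and so the largest step seen at this aromatic carbon, and it also gives a 2.0-fold higher number from compound 1 to compound 3 (0.31 log units; beyond the scatter) so that the order across these three compounds runs bromo, fluoro, methyl. Exchanging one heavy atom for one heavy atom is thus enough to separate them, and compound 3 is the weakest of the three here. Nothing given here accounts for this order. From the compounds shown here alone, whether a chloro group, an amine or a carboxylic acid at this carbon would stand nearer bromo or methyl stays open. So does whether the same order holds elsewhere on the shared core.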